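The source may hold more compounds than are shown below. What is called first, only, known or untested is meant among the compounds shown, and "the series" means these compounds.

Compound 1 `CC1(C)C=C(n2ccccc2=O)c2cc(S(N)(=O)=O)ccc2O1`: 69.2 nM
Compound 2 `CN(c1ccccc1)S(=O)(=O)c1ccc2c(c1)C(n1ccccc1=O)=CC(C)(C)O2`: 1.74 nM

Among the measured compounds shown here, in a functional assay with Rattus norvegicus as the target (a higher number here means that more compound is needed for the effect, a lower number that less compound is needed), compound 2 holds the lower of the two numbers, with compound 1 standing a 40-fold lower number from compound 1 to compound 2 (1.60 log units; beyond the scatter) apart as its only neighbour. Compound 3 `CC1(C)C=C(n2ccccc2=O)c2cc(S(=O)(=O)Oc3ccccc3)ccc2O1` differs from compound 2 by phenoxy in place of methyl(phenyl)amino on a sulfonyl sulfur. For the measured compounds named here, no measured step describes this exchange; the sole measured step, a 40-fold lower number from compound 1 to compound 2 (1.60 log units; beyond the scatter), shows that placing a phenyl-bearing group on the sulfonyl sulfur lowered the number sharply, and compound 3 keeps such a ring there. A small rise a 2.3-fold higher number from compound 2 to compound 3 (0.36 log units; beyond the scatter) is therefore expected, since nothing measured supports a larger change. Compound 3 is estimated at 4 nM, within 1 nM to 20 nM.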

Compound 3, half-maximal effective concentration: 2.51 nM
Estimate against measurement, compound 3: 1.6-fold (0.20 log units) above; the measured number falls inside the stated range.
By their numbers in this assay, from the lowest: compounds 2 and 3 (each within the scatter of the next); then compound 1.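

In this assay, phenoxy in place of methyl(phenyl)amino on a sulfonyl sulfur gives a 1.4-fold higher number from compound 2 to compound 3 (0.16 log units; within the scatter) and so leaves the two groups indistinguishable at this place. Set against the amino of compound 1, phenoxy gives a 28-fold lower number from compound 1 to compound 3 (1.44 log units; beyond the scatter) and so shows that the large step is not confined to a nitrogen-linked group. Nothing available explains why these two groups behave alike. Whether the aromatic ring itself is needed remains open, as the compounds shown include neither methoxy nor methylamino on this sulfur. On these data alone, how a benzyloxy group would compare also remains open.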